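This account rests on a few compounds, and the source may have more. Where it says the series, first, only, none or still open, it means among the compounds named here.

Three sulfonamides were compared for antagonism at the endothelin receptor, each pairing an aryl sulfonyl part with a five-membered aromatic ring on the sulfonamide nitrogen. Compound 1 `Cc1noc(NS(=O)(=O)c2cccc([N+](=O)[O-])c2)c1C` gives 7800 nM in an assay on VSM-A10 cells for antagonist activity at Endothelin-1 receptor (Rattus norvegicus); on this read-out lower numbers stand for stronger inhibition and higher numbers for weaker inhibition. Compound 2 `CCCNc1ccc(S(=O)(=O)Nc2onc(C)c2C)cc1` gives 27000 nM in this assay. Compound 3 `Cc1onc(NS(=O)(=O)c2cccc3c(N(C)C)cccc23)c1C`, which differs from the other two in its aryl sulfonyl part, gives 60 nM in this assay and stands lowest of the three; its separation from compound 1 and from compound 2 lies well beyond the usual scatter, so compound 3 is the most potent of the measured set.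

Compound 4 `CCc1noc(NS(=O)(=O)c2cccc3c(N(C)C)cccc23)c1C` keeps the aryl sulfonyl part of compound 3 and alters only the heterocycle on the sulfonamide nitrogen: 3-ethyl-4-methyl-1,2-oxazol-5-yl in place of 4,5-dimethyl-1,2-oxazol-3-yl on a sulfonamide nitrogen. Among the compounds with values here, no measured pair isolates this change, so its direction cannot be read from the existing numbers. Given that the ring keeps its hetero atoms and its acceptor count, the step from compound 3 to compound 4 in this assay is expected to be small, at or only just beyond the scatter, and more likely towards a weaker than a stronger number, giving an estimated step of a 1.8-fold higher number from compound 3 to compound 4 (0.26 log units; within the scatter). Compound 4 is therefore expected to give about 110 nM in this assay, within a range from 30 nM to 400 nM.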

Compound 4, half-maximal inhibitory concentration: 1170 nM
Beside the measured number, compound 4's estimate is 11-fold (1.03 log units) below it, outside the stated range (above it).
By their numbers in this assay, from the lowest: compound 3; then compound 4; then compound 1; then compound 2.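

In this assay, within the data shown here, the heterocycle on the sulfonamide nitrogen proves to be a sensitive place: with the aryl sulfonyl part held constant, exchanging 4,5-dimethyl-1,2-oxazol-3-yl for 3-ethyl-4-methyl-1,2-oxazol-5-yl gives a 20-fold higher number from compound 3 to compound 4 (1.29 log units; beyond the scatter), a large step that the earlier compounds, which offered no pair differing in one place, could not reveal. The step also shows that keeping the same five-membered aromatic ring type, the same counts of hydrogen-bond donors and acceptors, and no net charge does not preserve the potency seen with the group that leaves. No available evidence accounts for the size of this step.

The change alters the point of attachment to the ring and the substituents on it in a single move, so the compounds shown cannot apportion the step between these features. They also leave open whether another group on this ring, such as a butyl chain or an amine, would bring the number back down or push it higher, and whether the same step would hold with a different aryl sulfonyl part.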